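Replacing the Basic Side Chain with a Sulfonylpiperidine

This account rests on a few compounds, and the source may have more. Where it says the series, first, only, none or still open, it means among the compounds named here.

Measured so far, in a functional assay for antagonist activity at melanin-concentrating hormone receptor 1 (Homo sapiens); a lower number here means a stronger inhibitor, a higher number a weaker inhibitor:
- compound 1 `CC(C)N(CCN(C(=O)Nc1ccc(F)c(Cl)c1)C1CC[C@]2(c3cccc(C#N)c3)CC2C1)C(C)C` gives 4.98 nM
- compound 2 `CC(=O)NCc1cccc([C@]23CCC(N(CCN(C(C)C)C(C)C)C(=O)Nc4ccc(F)c(Cl)c4)CC2C3)c1` gives 31 nM

Going by the values given here, compound 1 stands lowest of the two numbers, and the only measured step, a 6.2-fold higher number from compound 1 to compound 2 (0.79 log units; beyond the scatter), comes from acetamidomethyl in place of cyano on an aromatic carbon. Compound 3 `CS(=O)(=O)N1CCC(CN(C(=O)Nc2ccc(F)c(Cl)c2)C2CC[C@]3(c4cccc(C#N)c4)CC3C2)CC1` keeps the cyano and changes a different part of compound 1: 1-(methylsulfonyl)piperidin-4-yl in place of (diisopropylamino)methyl on a saturated chain carbon bound to an amide-type nitrogen. Among the compounds with values here, no measured step touches this side chain, so the change from compound 1 to compound 2 offers no direct guide to it; it only shows that a single change elsewhere moved the number by a modest amount. With nothing closer to rest on, a rise of similar or somewhat larger size is expected, an 8.0-fold higher number from compound 1 to compound 3 (0.90 log units; beyond the scatter), but the uncertainty is wide in both directions. Compound 3 is therefore estimated at 40 nM in this assay, with a likely range from 5 nM to 300 nM.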

Compound 3, inhibition constant: 7.19 nM
Compound 3: middle estimate off by 5.6-fold (0.75 log units), on the high side; measured number inside the range.
By their numbers in this assay, from the lowest: compounds 1 and 3 (each within the scatter of the next); then compound 2.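

Putting 1-(methylsulfonyl)piperidin-4-yl in place of (diisopropylamino)methyl gives a 1.4-fold higher number from compound 1 to compound 3 (0.16 log units; within the scatter) in this assay and leaves the two compounds indistinguishable. On this saturated chain carbon bound to an amide-type nitrogen, the diisopropylamino group is therefore not required for a number in this range on the core of compound 1, even though the entering group adds a six-membered ring, a sulfur and two oxygens. Nothing available explains why two such different groups score alike.

As far as these compounds go, it remains open whether the methylsulfonyl group matters, which a piperidine with a free ring amine or an acetyl group in its place would help to test. Also open, from the compounds shown here alone, is whether acetamidomethyl in place of cyano would raise the number on the core of compound 3 as it does with the diisopropylamino side chain.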